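Notes on the aryl change from compound 3 to compound 4

The compounds below may be only part of what the source reports. "The series", "measured", "known", "first", "only" and "open" are said of these compounds alone.

Measured so far:
Compound 1, `N#Cc1c(N2CCC(c3cccc(F)c3)CC2)ccn(CC2CC2)c1=O`, 268%
Compound 2, `N#Cc1c(N2CCC(c3ccc(F)cc3)CC2)ccn(CC2CC2)c1=O`, 258%
Compound 3, `N#Cc1c(N2CCC(c3ccccc3Cl)CC2)ccn(CC2CC2)c1=O`, 259%

All three share one core and differ only in the aryl group on the saturated ring carbon. In a functional assay on CHO cells for positive allosteric modulation of metabotropic glutamate receptor 2 (Homo sapiens), with a stated time of 30 min (a higher number here means a larger maximal response, a lower number a smaller maximal response), compound 1 gives 268%, compound 2 gives 258% and compound 3 gives 259%. Compound 3 stands second highest of the three numbers, but its gap to compound 2 and its gap to compound 1 both lie within the scatter, so the three read as one level. The measured steps are a number 10 percentage points lower from compound 1 to compound 2 (within the scatter), a number 9 percentage points lower from compound 1 to compound 3 (within the scatter) and a number 1 percentage points higher from compound 2 to compound 3 (within the scatter); none goes beyond the scatter, and the aryl changes seen so far have left the maximal response where it was.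

Compound 4, `N#Cc1c(N2CCC(c3ccc(F)cc3F)CC2)ccn(CC2CC2)c1=O`, is not yet measured. It differs from compound 3 as follows: 2,4-difluorophenyl in place of 2-chlorophenyl on a saturated ring carbon. Among the compounds with values here, the steps that bear on this change are the two that alter the aryl group of compound 3, a number 9 percentage points lower from compound 1 to compound 3 (within the scatter) and a number 1 percentage points higher from compound 2 to compound 3 (within the scatter), both small. Within the data shown here, no measured step touches a group with two fluorines, so the change is judged by analogy only. No step beyond the scatter is expected in this assay. Compound 4 is therefore expected to give about 260%, within 235% to 285%, which means an expected step of a number 1 percentage points higher from compound 3 to compound 4 (within the scatter).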

Compound 4, largest response reached (Emax), in percent of the reference or control that the assay uses: 272%
Compound 4: middle estimate off by 12 percentage points, on the low side; measured number inside the range.
By their numbers in this assay, from the lowest: compounds 2, 3, 1 and 4 (each within the scatter of the next, the first and the last beyond it).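

In this assay, within the data shown here, the aryl group on the saturated ring carbon no longer reads as a single flat level: a number 13 percentage points higher from compound 3 to compound 4 (beyond the scatter) and a number 14 percentage points higher from compound 2 to compound 4 (beyond the scatter) are the first steps to pass the scatter, and the second of these is one small edit, fluoro in place of hydrogen on an aromatic carbon. The picture is only partial, since a number 4 percentage points higher from compound 1 to compound 4 (within the scatter), so the 2,4-difluorophenyl and 3-fluorophenyl groups stand on one level, and compound 1 goes against any reading that a second fluoro is needed to reach the top of this small range. The data at hand offer no explanation for these modest steps.

The compounds shown leave open whether the gain of compound 4 over compound 2 and compound 3 would hold for other groups with two halogens, such as 2,4-dichlorophenyl or 3,4-difluorophenyl. They also leave open how far this position tolerates a different kind of substituent on the phenyl ring, such as methoxy, a dimethylamino group or a carboxylic acid.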